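Compound 3 to compound 4: benzoyl to ethoxycarbonyl

This account rests on a few compounds, and the source may have more. Where it says the series, first, only, none or still open, it means among the compounds named here.

In a physicochemical assay for lipophilicity, at pH 7.4 (on this read-out higher numbers stand for higher lipophilicity and lower numbers for lower lipophilicity), compound 3 `Cc1cc(NC(=O)c2ccccc2)nn1Cc1cc(Cl)ccc1OCc1ccccc1` gives > 3.7, which is a limit and not a number. Compound 1 `Cc1cc(NC(=O)C2CCOC2)nn1Cc1cc(Cl)ccc1OCc1ccccc1` gives > 3.7, also a limit. Compound 2 `Cc1cc(NC(=O)C2CCOCC2)nn1Cc1cc(Cl)ccc1OCc1ccccc1` gives > 3.7, again a limit. Compound 3 therefore stands at the limit of > 3.7 in this assay, at which 3 of the 3 values shown sit.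

Compound 4 `CCOC(=O)Nc1cc(C)n(Cc2cc(Cl)ccc2OCc2ccccc2)n1` differs from compound 3 by ethoxy in place of phenyl on a carbonyl carbon. The measured changes on this carbonyl carbon are a step that the two limits leave unreadable from compound 1 to compound 3 and a step that the two limits leave unreadable from compound 2 to compound 3. Neither gives a size to carry over, so only a small downward move is expected, and not with confidence. The expected change in this assay is a step that the limit leaves unreadable from compound 3 to compound 4. Compound 4 is estimated at 4, with an expected range of 3.6 to 4.5.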

Compound 4, distribution coefficient: > 3.7
Compound 4 ended at the assay's limit; the forecaster's own chance of this, stated with the estimate: 80%; the middle value lies beyond the limit too.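

Compound 4 gives > 3.7, which is a limit and not a number. No step among compound 1, compound 2, compound 3 and compound 4 can be read in this assay: the limit of > 3.7 in this assay, at which 4 of the 4 values shown sit.

As far as these compounds go, how far ethoxy, phenyl, oxan-4-yl and oxolan-3-yl on the carbonyl carbon separate these compounds in this assay remains open.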